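This account rests on a few compounds, and the source may have more. Where it says the series, first, only, none or still open, it means among the compounds named here.

Compound 1 `NS(=O)(=O)c1ccc(N2N=C(c3ccccc3)CC2c2ccccc2F)cc1`: 28000 nM
Compound 2 `Cc1ccc(C2CC(c3ccc(Oc4ccccc4)cc3)=NN2c2ccc(S(N)(=O)=O)cc2)cc1`: 86000 nM
Compound 3 `NS(=O)(=O)c1ccc(N2N=C(c3ccc(Oc4ccccc4)cc3)CC2c2ccc(F)cc2)cc1`: 25000 nM

In an ADME assay on Vero 76 cells (Chlorocebus sabaeus) for cytotoxicity, read by MTT assay, with a stated time of 96 h (a higher number here means that more compound is tolerated, a lower number that less compound is tolerated), compound 3 sits level with compound 1, as their two values lie within the scatter of each other. Compound 2 stands apart with the highest number of the three, tolerated at a clearly greater concentration.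

The next molecule, compound 4 `NS(=O)(=O)c1ccc(N2N=C(c3ccc(Oc4ccccc4)cc3)CC2c2ccccc2F)cc1`, keeps the same atoms as compound 3 but joins them differently. It carries 2-fluorophenyl in place of 4-fluorophenyl on a saturated ring carbon.

Within the data shown here, only one measured step involves a single change, a 3.4-fold lower number from compound 2 to compound 3 (0.54 log units; beyond the scatter). Among the measured compounds shown here, it swaps fluoro for methyl on an aromatic carbon, so it says little about moving a fluorine, and no measured pair isolates such a move. The closest evidence is compound 1 at 28000 nM, which also carries 2-fluorophenyl but differs from compound 4 elsewhere. Its value gives no sign that 2-fluorophenyl brings a large shift, so no step beyond the scatter is expected, in either direction.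

The estimate amounts to a 1.1-fold higher number from compound 3 to compound 4 (0.03 log units; within the scatter), which is expected to be small. Compound 4 is expected at 27000 nM, with an estimated range of 12000 nM to 60000 nM.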

Compound 4, half-maximal cytotoxic concentration: 96000 nM
Compound 4: the middle estimate sits 3.6-fold (0.55 log units) below what was measured, and the stated range ends below it.
By their numbers in this assay, from the lowest: compounds 3 and 1 (each within the scatter of the next); then compounds 2 and 4 (each within the scatter of the next).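

In this assay, moving the fluorine on the phenyl ring at this saturated ring carbon gives a 3.8-fold higher number from compound 3 to compound 4 (0.58 log units; beyond the scatter), so the same atoms joined differently are enough to shift the number beyond the scatter. Among these compounds, this is the first sign that where the fluorine sits on this group counts, not merely that a fluorine is there. At the same position, 2-fluorophenyl in place of 4-methylphenyl gives a 1.1-fold higher number from compound 2 to compound 4 (0.05 log units; within the scatter), which leaves those two groups level, while phenoxy in place of hydrogen on an aromatic carbon, with 2-fluorophenyl kept, gives a 3.4-fold higher number from compound 1 to compound 4 (0.54 log units; beyond the scatter), so a change elsewhere on the molecule also moves the number. Nothing measured here explains why the fluorine's place matters in this assay.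

The compounds shown leave open how 3-fluorophenyl would compare, and whether 2-chlorophenyl or 2-methylphenyl would stand with 2-fluorophenyl or with 4-fluorophenyl. They also leave open whether phenoxy gives a similar step when 4-fluorophenyl, rather than 2-fluorophenyl, sits at the saturated ring carbon.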